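A few compounds are considered here, and "the series" means these few. Any claim that something is new, unique, unknown or untested is made for them only; others in the source may bear on it.

Of the compounds shown here, three have so far been measured in a functional assay (lung) for inhibition, with Cavia porcellus as the target; a higher number here means a weaker inhibitor, a lower number a stronger inhibitor. Compound 1 `CC(CCc1nnn[nH]1)Cc1ccc(OCc2ccc3ccccc3n2)cc1` gives 27 nM there, compound 2 `CCCC(CCc1nnn[nH]1)Cc1ccc(OCc2ccc3ccccc3n2)cc1` gives 32 nM, and compound 3 `CCCC(CCc1nnn[nH]1)Cc1cccc(OCc2ccc3ccccc3n2)c1` gives 16 nM. Compound 2 and compound 1 differ in a single place, (hydrogen in place of ethyl on a saturated chain carbon, three bonds along the chain from an aromatic carbon), and the step of a 1.2-fold lower number from compound 2 to compound 1 (0.07 log units; within the scatter). Compound 3 and compound 2 are built from the same atoms joined differently; the difference between the two cores is not broken down here. The unmeasured compound 4 `CC(CCc1nnn[nH]1)Cc1cccc(OCc2ccc3ccccc3n2)c1` stands to compound 3 exactly as compound 1 stands to compound 2: hydrogen in place of ethyl on a saturated chain carbon, three bonds along the chain from an aromatic carbon, at the same place. Because the earlier step of a 1.2-fold lower number from compound 2 to compound 1 (0.07 log units; within the scatter) stayed within the scatter, the step expected from compound 3 to compound 4 in this assay is a 1.1-fold lower number from compound 3 to compound 4 (0.03 log units; within the scatter). Compound 4 is accordingly estimated at 15 nM, with a range from 7 nM to 32 nM expected.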

Compound 4, half-maximal inhibitory concentration: 150 nM
For compound 4 the middle estimate is 10-fold (1.00 log units) below the measured one, and the stated range ends below it.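

In this assay, hydrogen in place of ethyl gives a 9.4-fold higher number from compound 3 to compound 4 (0.97 log units; beyond the scatter) on the core of compound 3, whereas the same change stayed within the scatter on the core of compound 2. For these four compounds, the effect of the change therefore depends on the core, and a step read on one core cannot simply be carried over to the other. The comparison does not show what in the two cores causes this, and two cores cannot tell how the change will behave on a third, but the gap itself is clear: the same change on two cores in this assay, a 1.2-fold lower number (0.07 log units; within the scatter) from compound 2 to compound 1 and a 9.4-fold higher number (0.97 log units; beyond the scatter) from compound 3 to compound 4, 11-fold (1.05 log units) apart, beyond the scatter of two such steps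

The compounds shown leave open how a longer chain such as butyl, or a carboxylic acid, on that same saturated chain carbon would read on either core. They also leave open whether the gap between the two cores would hold for a smaller change at that carbon.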